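The source may hold more compounds than are shown below. What is called first, only, known or untested is meant among the compounds shown, and "the series" means these compounds.

Measured so far:
Compound 1, `C#CCO/C=C/C(=O)OC` — in a functional assay on SW1573 cells (Homo sapiens) for antiproliferative activity, read by sulforhodamine B assay, with a stated time of 48 h (a lower number here means a stronger inhibitor of growth, a higher number a weaker inhibitor of growth), compound 1 gives > 100000 nM, which is a limit of the assay and not a number.
Compound 2, `COC(=O)C#CC(O/C=C/C(=O)OC)C(C)C` — in this assay compound 2 gives 750 nM.
Compound 3, `CCOC(=O)C#CC(O/C=C/C(=O)OC)C(C)C` — in this assay compound 3 gives 960 nM.

Compound 2 gives the lowest of the two numbers shown, with compound 3 close to it: a 1.3-fold higher number from compound 2 to compound 3 (0.11 log units; within the scatter). Compound 4, `COC(=O)C#CC(C)O/C=C/C(=O)OC`, differs from compound 2 as follows: methyl in place of isopropyl on a saturated chain carbon bound to an oxygen on an unsaturated carbon and a triple-bonded carbon. No measured step alters this part of the structure; the only step shown, from compound 2 to compound 3, changes the ester and stays within the scatter, so it bears little on the change to compound 4. Compound 1 gives only a limit. For compound 4 a modestly weaker number is therefore expected, 2000 nM (range 500 nM to 8000 nM), a step of a 2.7-fold higher number from compound 2 to compound 4 (0.43 log units; beyond the scatter).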

Compound 4, concentration for 50% growth inhibition: 1700 nM
The estimate for compound 4 lay 1.2-fold (0.07 log units) above the measured number; low and high end bracket the measured number.
By their numbers in this assay, from the lowest: compounds 2, 3 and 4 (each within the scatter of the next, the first and the last beyond it). At a limit, above all of these: compound 1.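

The position on the saturated chain carbon bound to an oxygen on an unsaturated carbon and a triple-bonded carbon responds to change, unlike the ester: replacing isopropyl with methyl gives a 2.3-fold higher number from compound 2 to compound 4 (0.36 log units; beyond the scatter) in this assay. The step is modest, so growth inhibition does not depend on isopropyl being present at this carbon, although isopropyl gives the lower number of the pair. No measurement shown here accounts for this difference.

Two groups at this carbon do not establish a trend with size. Going by these compounds, how a longer chain, a phenyl ring or an amine there would behave remains open.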